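Swapping the Nitrophenylsulfonyl Arm for an Ethyl Carbamate

A few compounds are considered here, and "the series" means these few. Any claim that something is new, unique, unknown or untested is made for them only; others in the source may bear on it.

compound 1, `CCN(CC)c1ccc2cc(C(=O)c3ccc(N4CCN(S(=O)(=O)c5ccc(Br)cc5)CC4)cc3)oc2c1`: > 40000 nM (a limit of the assay)
compound 2, `CCN(CC)c1ccc2cc(C(=O)c3ccc(N4CCN(S(=O)(=O)c5ccc([N+](=O)[O-])cc5)CC4)cc3)oc2c1`: 1860 nM

In a functional assay on SGC-7901 cells (Homo sapiens) for cytotoxicity, read by MTT assay, with a stated time of 48 h (a lower number here means a stronger inhibitor, a higher number a weaker inhibitor), compound 1 gives > 40000 nM, which is a limit of the assay and not a number. In this assay compound 2 gives 1860 nM, the only number shown. Among the compounds with values here, the only other value is the limit of > 40000 nM in this assay, at which 1 of the 2 values shown sits. Within the data shown here, the single measured step is an at least 21-fold lower number from compound 1 to compound 2 (1.33 log units; beyond the scatter), a change on the part that now leaves. Among the measured compounds shown here, compound 3, `CCOC(=O)N1CCN(c2ccc(C(=O)c3cc4ccc(N(CC)CC)cc4o3)cc2)CC1`, differs from compound 2 by ethoxycarbonyl in place of (4-nitrophenyl)sulfonyl on an amine nitrogen in a ring, so no measured step bears directly on it. Compound 3 is expected to give a higher number, a 4.3-fold higher number from compound 2 to compound 3 (0.63 log units; beyond the scatter). The estimate for compound 3 is 8000 nM, between 1500 nM and 40000 nM.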

Compound 3, half-maximal inhibitory concentration: > 40000 nM
Compound 3 gave a limit, no number; the forecaster's own chance of this, stated with the estimate: 30%; middle value at least 5.0-fold (0.69 log units) away from the limit.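

In this assay, ethoxycarbonyl in place of (4-nitrophenyl)sulfonyl on the amine nitrogen in the ring gives an at least 21-fold higher number from compound 2 to compound 3 (1.33 log units; beyond the scatter), so the measurable number depends on the whole arm at this nitrogen and not only on the group at its aromatic carbon. The value of compound 3 is a limit of the assay, not a number: the limit of > 40000 nM in this assay, at which 2 of the 3 values shown sit. The step between the two compounds at this limit cannot be read. Going by these compounds, it remains open whether a plain phenylsulfonyl, an acetyl or a nitrile-bearing phenylsulfonyl on this nitrogen would give a number in this assay.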